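Swapping 2,3,5-trichlorophenyl for 4-methoxyphenyl in a growth test

A few compounds are considered here, and "the series" means these few. Any claim that something is new, unique, unknown or untested is made for them only; others in the source may bear on it.

In a functional assay on DU-145 cells (Homo sapiens) for inhibition, read by trypan blue exclusion, with a stated time of 96 h (on this read-out higher numbers stand for weaker inhibition of growth and lower numbers for stronger inhibition of growth), compound 2 (`O=C(/C(=C\c1cc(Cl)cc(Cl)c1Cl)S(=O)(=O)Cc1ccc(Cl)cc1)c1ccc(Br)cc1`) gives 1000 nM as the lower of two numbers. On the same read-out compound 1 (`COc1ccc(/C=C(\C(=O)c2ccc(Br)cc2)S(=O)(=O)c2ccc(Br)cc2)cc1`) gives 25000 nM. The gap between the two lies beyond the usual scatter. Compound 3 (`COc1ccc(/C=C(\C(=O)c2ccc(Br)cc2)S(=O)(=O)Cc2ccc(Cl)cc2)cc1`) has 4-methoxyphenyl in place of 2,3,5-trichlorophenyl on a double-bonded chain carbon bound to a double-bonded chain carbon. Going by the values given here, no measured pair shows this change alone, so the guide is thin. Compound 1 also carries 4-methoxyphenyl and stands at 25000 nM on the weaker side of the pair, so a rise in the number is expected in this assay and is expected to pass the scatter. The estimated step of a 5.0-fold higher number from compound 2 to compound 3 (0.70 log units; beyond the scatter) means weaker inhibition of growth. Compound 3 is estimated at 5000 nM within an expected range from 1500 nM to 20000 nM on this read-out.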

Compound 3, concentration for 50% growth inhibition: 25000 nM
Estimate against measurement, compound 3: 5.0-fold (0.70 log units) below; measured number above the stated range.
By their numbers in this assay, from the lowest: compound 2; then compounds 1 and 3 (each within the scatter of the next).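

In this assay the change from 2,3,5-trichlorophenyl to 4-methoxyphenyl on a double-bonded chain carbon bound to a double-bonded chain carbon can now be read on its own: it gives a 25-fold higher number from compound 2 to compound 3 (1.40 log units; beyond the scatter) and so a large loss of growth inhibition. With 4-methoxyphenyl in place, the group on the sulfonyl sulfur makes no visible difference, as 4-chlorobenzyl in place of 4-bromophenyl gives no change at the digits printed from compound 1 to compound 3 (within the scatter) in this pair. Nothing measured here gives a reason for either result.

Going by these compounds, whether the sulfonyl group would also make no difference alongside 2,3,5-trichlorophenyl remains open. Also open, on these data alone, is which part of the larger change matters, as a plain phenyl, a phenyl with a single chlorine or an aminophenyl at this position could help separate losing the chlorines from gaining the methoxy group.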